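The source may report more compounds than this note shows. Statements on the series, on what has been measured and on what is new or still open speak of the compounds shown alone.

Compound 1, `O=C(NCc1ccc(S(=O)(=O)c2ccccc2)cc1)c1cc2ncccc2s1`, is the starting point of this account. In a functional assay on A2780 cells (Homo sapiens) for inhibition, read by sulforhodamine B assay, with a stated time of 72 h (a higher number here means a weaker inhibitor, a lower number a stronger inhibitor), compound 1 gives > 10000 nM, which is a limit of the assay and not a number. That puts compound 1 at the limit of > 10000 nM in this assay, at which 2 of the 3 values shown sit. Compound 3, `O=C(NCc1ccc(S(=O)(=O)N2CCCCC2)cc1)c1ccn2ccnc2c1`, likewise gives > 10000 nM in this assay, again a limit rather than a number. Compound 2, `O=C(NCc1ccc(S(=O)(=O)c2cccc(C(F)(F)F)c2)cc1)c1cnc2nccn2c1`, gives 2 nM in this assay. Compound 4, `O=C(NCc1ccc(S(=O)(=O)c2ccccc2)cc1)c1c[nH]c2ccncc12`, differs from compound 1 in one place: a group of 9 heavy atoms (7 carbon, 2 nitrogen; one five-membered aromatic ring with 1 hetero atom, one six-membered aromatic ring with 1 hetero atom) in place of a group of 9 heavy atoms (7 carbon, 1 nitrogen, 1 sulfur; one five-membered aromatic ring with 1 hetero atom, one six-membered aromatic ring with 1 hetero atom), on a carbonyl carbon. Among the measured compounds shown here, no measured step starts from compound 1, so the size of this change in this assay can only be expected, not read; a move towards stronger inhibition seems possible but far from certain. Compound 4 is therefore expected to give 2000 nM, within 200 nM to 10000 nM, the expected step of an at least 5.0-fold lower number from compound 1 to compound 4 (0.69 log units; beyond the scatter) remaining a guess.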

Compound 4, half-maximal inhibitory concentration: 2100 nM
Compound 4: middle estimate off by 1.1-fold (0.02 log units), on the low side; the measured number falls inside the stated range.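

Changing only the group on the carbonyl carbon gives a readable shift in this assay, an at least 4.7-fold lower number from compound 1 to compound 4 (0.67 log units; beyond the scatter), so this position affects the read-out while the rest of the molecule stays fixed. Going by these compounds, the true size of the step remains unknown, because the value for compound 1 is a limit: the limit of > 10000 nM in this assay, at which 2 of the 4 values shown sit. The entering group has 1 hydrogen-bond donor and the leaving group has none, but this single pair cannot tie the step to that difference. The compounds shown leave open how a morpholine or a carboxylic acid on the carbonyl carbon would fare in this assay.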